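The source may hold more compounds than are shown below. What is called first, only, known or untested is meant among the compounds shown, and "the series" means these compounds.

Among the compounds measured in a functional assay on NCI-H460 cells (Homo sapiens) for antiproliferative activity, read by sulforhodamine B assay, with a stated time of 72 h (a lower number here means a stronger inhibitor, a higher number a weaker inhibitor), compound 3 `CN(CCNCc1cn(Cc2nc3cc(Cl)ccc3[nH]2)nn1)CCNc1ccnc2cc(Cl)ccc12` gives 59000 nM, the highest of the two plain numbers available. Its nearest neighbour is compound 1 `CN(CCNCc1cn(-c2ccccc2)nn1)CCNc1ccnc2cc(Cl)ccc12`, which gives 25000 nM. Compound 2 `CN(CCNCc1cn(CC(=O)O)nn1)CCNc1ccnc2cc(Cl)ccc12` reaches only a limit of the assay, > 200000 nM. All three share one core and differ only in the group carried on an aromatic nitrogen of the five-membered ring. Compound 4 `CN(CCNCc1cn(-c2ccnc3cc(Cl)ccc23)nn1)CCNc1ccnc2cc(Cl)ccc12` changes that group once more: 7-chloroquinolin-4-yl in place of (5-chloro-1H-benzimidazol-2-yl)methyl on an aromatic nitrogen. Among the measured compounds shown here, three measured steps bear on this position. There is an at least 8.0-fold higher number from compound 1 to compound 2 (0.90 log units; beyond the scatter), there is a 2.4-fold higher number from compound 1 to compound 3 (0.37 log units; beyond the scatter), and there is an at least 3.3-fold lower number from compound 2 to compound 3 (0.53 log units; beyond the scatter). A flat aromatic group bound directly to that nitrogen, as in compound 1, has so far gone with the lowest number, and compound 4 returns to that arrangement with a larger aromatic group. On the basis of a 2.4-fold higher number from compound 1 to compound 3 (0.37 log units; beyond the scatter) run in reverse, the change is expected to give a 3.0-fold lower number from compound 3 to compound 4 (0.47 log units; beyond the scatter). Compound 4 is estimated at 20000 nM, with a likely range from 6000 nM to 70000 nM.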

Compound 4, half-maximal inhibitory concentration: 16000 nM
Compound 4: the middle estimate sits 1.3-fold (0.10 log units) above what was measured, within the range that was stated.
By their numbers in this assay, from the lowest: compounds 4 and 1 (each within the scatter of the next); then compound 3. At a limit, above all of these: compound 2.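

Replacing phenyl with 7-chloroquinolin-4-yl on the aromatic nitrogen gives a 1.6-fold lower number from compound 1 to compound 4 (0.19 log units; within the scatter), so in this assay this larger aromatic group bound directly to that nitrogen reads the same as phenyl. The groups (5-chloro-1H-benzimidazol-2-yl)methyl and 7-chloroquinolin-4-yl each hold 11 heavy atoms, one of them chlorine, yet exchanging them gives a 3.7-fold lower number from compound 3 to compound 4 (0.57 log units; beyond the scatter), so equal atom counts do not mean equal numbers at this position. The carboxymethyl group gives a limit rather than a number, so its replacement by 7-chloroquinolin-4-yl reads only as an at least 12-fold lower number from compound 2 to compound 4 (1.09 log units; beyond the scatter): the limit of > 200000 nM in this assay, at which 1 of the 4 values shown sits.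

The compounds shown leave open how a plain alkyl chain or an amine on this nitrogen would read. They also leave open whether 5-chloro-1H-benzimidazol-2-yl, bound directly without its methyl link, would read like the directly bound groups of compound 1 and compound 4.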